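The source may hold more compounds than are shown below. What is called first, only, known or untested is meant among the compounds shown, and "the series" means these compounds.

Measured compounds:
Compound 1 `COc1ccc(C(=O)c2cc(OC)c(OC)c(OC)c2)cc1NC(=O)/C=C/c1cc(OC)c(OC)c(OC)c1` — 2100 nM
Compound 2 `COc1cc(/C=C/C(=O)Nc2cc(C(=O)c3cc(OC)c(OC)c(OC)c3)ccc2OC)ccc1F` — 15500 nM
Compound 3 `COc1cc(C(=O)c2cc(OC)c(OC)c(OC)c2)cc(NC(=O)/C=C/c2cc(OC)c(OC)c(OC)c2)c1OC` — 3900 nM

In a functional assay on ME-180 cells (Homo sapiens) for cytotoxicity, read by MTT assay, with a stated time of 72 h (on this read-out higher numbers stand for weaker inhibition and lower numbers for stronger inhibition), compound 3 stands second highest of the three numbers. Its nearest neighbour is compound 1, and the step between them, a 1.9-fold higher number from compound 1 to compound 3 (0.27 log units; within the scatter), lies within the scatter, so the two cannot be ranked against each other. Compound 2 stands clearly higher, and the step of a 7.4-fold higher number from compound 1 to compound 2 (0.87 log units; beyond the scatter) is beyond the scatter.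

Compound 4 `COc1ccc(/C=C/C(=O)Nc2cc(C(=O)c3cc(OC)c(OC)c(OC)c3)cc(OC)c2OC)cc1OC` has not yet been measured. It differs from compound 3 by hydrogen in place of methoxy on an aromatic carbon; cut one bond further out, the change reads 3,4,5-trimethoxyphenyl to 3,4-dimethoxyphenyl on the double-bonded chain.

Among the compounds with values here, only one measured step touches the same ring: a 7.4-fold higher number from compound 1 to compound 2 (0.87 log units; beyond the scatter), where the 3,4,5-trimethoxyphenyl on the chain was exchanged for 4-fluoro-3-methoxyphenyl and the number rose modestly. The change to compound 4 is smaller, removing a single methoxy and leaving two in place. The step of a 1.9-fold higher number from compound 1 to compound 3 (0.27 log units; within the scatter) concerns a different ring and bears little on it.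

A moderate rise is therefore expected for compound 4, a 2.1-fold higher number from compound 3 to compound 4 (0.31 log units; beyond the scatter), smaller than the step seen for compound 2. Compound 4 is estimated at 8000 nM in this assay, with a range from 3000 nM to 25000 nM.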

Compound 4, half-maximal inhibitory concentration: 6700 nM
Beside the measured number, compound 4's estimate is 1.2-fold (0.08 log units) above it; the measured number falls inside the stated range.
By their numbers in this assay, from the lowest: compounds 1, 3 and 4 (each within the scatter of the next, the first and the last beyond it); then compound 2.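

On the core of compound 3, the exchange of 3,4,5-trimethoxyphenyl for 3,4-dimethoxyphenyl puts hydrogen in place of a single methoxy, ortho to a methoxy group, and in this assay this step (a 1.7-fold higher number from compound 3 to compound 4 (0.24 log units; within the scatter)) cannot be told apart from the scatter. The earlier compounds had shown this ring changed only on the core of compound 1 and only by the larger exchange for 4-fluoro-3-methoxyphenyl (a 7.4-fold higher number from compound 1 to compound 2 (0.87 log units; beyond the scatter)), a step beyond the scatter, so compound 4 adds the first reading for the removal of this methoxy alone: this methoxy can go without a step that can be read in this assay, on this core. No measurement offers an explanation for this reading of compound 4.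

The compounds shown leave open whether a hydroxyl, an amine or a chlorine in this same place would also stay within the scatter of compound 3. They also leave open how 3,4-dimethoxyphenyl would read on the core of compound 1, and whether removing a second methoxy from this ring would produce a step beyond the scatter.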